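The source may hold more compounds than are shown below. What is called first, only, known or untested is meant among the compounds shown, and "the series" means these compounds.

Compound 1, `CCOC(=O)c1c(-c2ccccc2)[nH]c2cc(OC)ccc2c1=O`, in an ADME assay on HepG2 cells (Homo sapiens) for cytotoxicity, read by luminescence, with a stated time of 72 h (on this read-out higher numbers stand for an effect only at larger amounts of compound and lower numbers for an effect already at smaller amounts), gives > 21500 nM, which is a limit of the assay and not a number. Compound 2, `CCOC(=O)c1c(-c2cccc(OC)c2)[nH]c2cc(OC)ccc2c1=O`, in this assay gives > 21500 nM, likewise a limit. Compound 3, `CCCCOc1cccc(-c2[nH]c3cc(OC)ccc3c(=O)c2C(=O)OCC)c1`, in this assay gives > 21500 nM, again a limit. Hence (the limit of > 21500 nM in this assay, at which 3 of the 3 values shown sit), and the steps a step that the two limits leave unreadable from compound 1 to compound 2, a step that the two limits leave unreadable from compound 1 to compound 3 and a step that the two limits leave unreadable from compound 2 to compound 3 cannot be sized.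

Compound 4, `CCOC(=O)c1c(-c2cccc(N(C)C)c2)[nH]c2cc(OC)ccc2c1=O`, differs from compound 1 by dimethylamino in place of hydrogen on an aromatic carbon. The substitutions on an aromatic carbon from compound 1 to compound 2 and to compound 3 bear on this change, but both left only limits. No step beyond the scatter is therefore expected in this assay, with the value for compound 4 most likely again a limit. The estimate for compound 4 is 30000 nM, within 15000 nM to 80000 nM. The expected step is a step that the limit leaves unreadable from compound 1 to compound 4.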

Compound 4, half-maximal effective concentration: > 21500 nM
Compound 4 gave a limit, no number (the forecaster's own chance of this, stated with the estimate: 80%); the middle value is on the limit's open side.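

Within the data shown here, compound 4, like compounds 1, 2 and 3, gives only a limit, so no step among them can be read: the limit of > 21500 nM in this assay, at which 4 of the 4 values shown sit.

Going by these compounds, whether any change on the shared core gives a real number in this assay stays open.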